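The source may hold more compounds than are shown below. What is called first, only, known or untested is meant among the compounds shown, and "the series" means these compounds.

- Compound 1 `COc1ccc(-c2ccc(-c3ccc(-c4nc5cc(C)ccc5[nH]4)cc3)cc2)cc1OC`: 2130 nM
- Compound 2 `COc1ccc(-c2ccc(-c3ccc(-c4nc5ccccc5[nH]4)cc3)cc2)cc1OC`: 21600 nM

In a functional assay on A2780 cells (Homo sapiens) for inhibition, read by sulforhodamine B assay (on this read-out higher numbers stand for weaker inhibition of growth and lower numbers for stronger inhibition of growth), compound 1 holds the lower of the two numbers, at 2130 nM. Compound 3 `Cc1ccc2[nH]c(-c3ccc(-c4ccc(-c5ccc(OC(F)(F)F)cc5)cc4)cc3)nc2c1` keeps its methyl and differs elsewhere, with 4-(trifluoromethoxy)phenyl in place of 3,4-dimethoxyphenyl on an aromatic carbon. Among the measured compounds shown here, the only measured step, a 10-fold higher number from compound 1 to compound 2 (1.01 log units; beyond the scatter), replaces that methyl with hydrogen, so no measurement tests this new change directly. For the measured compounds named here, that step does suggest a wide range, since one small edit moved the number so far. No direction can be argued, so the estimated step is a 1.1-fold lower number from compound 1 to compound 3 (0.03 log units; within the scatter). For compound 3 the expected value in this assay is 2000 nM, with an estimated range of 400 nM to 10000 nM.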

Compound 3, concentration for 50% growth inhibition: 12300 nM
For compound 3 the middle estimate is 6.2-fold (0.79 log units) below the measured one; measured number outside the range, above it.
By their numbers in this assay, from the lowest: compound 1; then compounds 3 and 2 (each within the scatter of the next).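

In this assay, among the compounds shown here, the methyl is no longer the only part of compound 1 seen to matter: replacing 3,4-dimethoxyphenyl with 4-(trifluoromethoxy)phenyl gives a 5.8-fold higher number from compound 1 to compound 3 (0.76 log units; beyond the scatter), which means weaker inhibition of growth. This position therefore affects the result too, even though the methyl stays in place. No measurement available here explains the loss. As far as these compounds go, it remains open whether the loss follows from losing the two methoxy groups or from gaining trifluoromethoxy. A 4-methoxyphenyl or 4-aminophenyl group at this position could help separate these two changes.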